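Replacing an iodophenyl arm with a carboxycyclohexyl arm

This account rests on a few compounds, and the source may have more. Where it says the series, first, only, none or still open, it means among the compounds named here.

- compound 1 `Oc1ccc(CN(Cc2cccc(C(F)(F)F)c2)Cc2ccc(O)c3ncccc23)c2cccnc12` gives 37 nM
- compound 2 `Oc1ccc(CN(Cc2cccc(I)c2)Cc2ccc(O)c3ncccc23)c2cccnc12` gives 394 nM

In a functional assay on PC-3 cells (Homo sapiens) for cytotoxicity, read by MTT assay (a lower number here means a stronger inhibitor, a higher number a weaker inhibitor), compound 2 has the higher of the two numbers, which makes it the weaker inhibitor of this pair. For the measured compounds named here, changing a single group on the aromatic ring gave an 11-fold higher number from compound 1 to compound 2 (1.03 log units; beyond the scatter) and this is the only measured step to go on. Compound 3 `O=C(O)C1CCC(CN(Cc2ccc(O)c3ncccc23)Cc2ccc(O)c3ncccc23)CC1` carries a larger change, with 4-carboxycyclohexyl in place of 3-iodophenyl on a saturated chain carbon bound to an amine nitrogen. The measured step concerned a smaller swap, and the data do not show the direction for this new group. A moderate rise is therefore expected, with wide uncertainty. The expected change is a 2.5-fold higher number from compound 2 to compound 3 (0.40 log units; beyond the scatter) and it remains only an estimate. For compound 3 the estimated value is 1000 nM with an expected range from 200 nM to 5000 nM in this assay's read-out.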

Compound 3, half-maximal inhibitory concentration: 9940 nM
Compound 3: the middle estimate sits 9.9-fold (1.00 log units) below what was measured, outside the stated range (above it).
By their numbers in this assay, from the lowest: compound 1; then compound 2; then compound 3.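

In this assay, the arm on a saturated chain carbon bound to an amine nitrogen matters even more than the earlier swap of one group on the aromatic ring suggested. Putting 4-carboxycyclohexyl in place of 3-iodophenyl gives a 25-fold higher number from compound 2 to compound 3 (1.40 log units; beyond the scatter), and putting it in place of 3-(trifluoromethyl)phenyl gives a 270-fold higher number from compound 1 to compound 3 (2.43 log units; beyond the scatter), so both steps make compound 3 the weakest inhibitor of the three. No measurement here explains why this change costs so much.

The change replaces an aromatic ring with a non-aromatic one and adds a carboxylic acid in the same step, and the compounds shown leave open which of the two goes with the weaker inhibition. A plain cyclohexyl arm and a 4-carboxyphenyl arm would pull these two changes apart.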